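Working notes: a second trifluoromethyl on the terminal aryl

The source may report more compounds than this note shows. Statements on the series, on what has been measured and on what is new or still open speak of the compounds shown alone.

Measured so far in a functional assay on SK-MEL-5 cells (Homo sapiens) for inhibition, read by sulforhodamine B assay, with a stated time of 48 h; on this read-out lower numbers stand for stronger inhibition of growth and higher numbers for weaker inhibition of growth:
compound 1 `O=C(Nc1cccc(-n2cc(-c3ccncc3)c(-c3ccc(Cl)c(O)c3)n2)c1)Nc1cccc(C(F)(F)F)c1` gives 4710 nM
compound 2 `O=C(Nc1cccc(-n2cc(-c3ccncc3)c(-c3ccc(Cl)c(O)c3)n2)c1)Nc1ccc(Cl)c(Cl)c1` gives 1160 nM

Compound 1 stands highest of the two numbers. Within the data shown here, the single measured step, a 4.1-fold lower number from compound 1 to compound 2 (0.61 log units; beyond the scatter), replaces the whole terminal aryl and so bears only loosely on the present change; it shows that this aryl moves the number modestly. Compound 3 `O=C(Nc1cccc(-n2cc(-c3ccncc3)c(-c3ccc(Cl)c(O)c3)n2)c1)Nc1cc(C(F)(F)F)cc(C(F)(F)F)c1` differs from compound 1 by trifluoromethyl in place of hydrogen on an aromatic carbon, meta to a trifluoromethyl group. A small downward step is expected, a 1.6-fold lower number from compound 1 to compound 3 (0.20 log units; within the scatter), close to the scatter. The estimate for compound 3 is 3000 nM, range 1000 nM to 9000 nM.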

Compound 3, concentration for total growth inhibition: 1250 nM
Compound 3: middle estimate off by 2.4-fold (0.38 log units), on the high side, within the range that was stated.
By their numbers in this assay, from the lowest: compounds 2 and 3 (each within the scatter of the next); then compound 1.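

In this assay, trifluoromethyl in place of hydrogen on an aromatic carbon, meta to a trifluoromethyl group, gives a 3.8-fold lower number from compound 1 to compound 3 (0.58 log units; beyond the scatter). This position on the terminal aryl therefore moves the number through a single added group, whereas the earlier step exchanged the whole aryl. No evidence at hand bears on the cause of this step. Going by these compounds, whether an amine or a carboxylic acid at this place would move the number in the same direction stays open, as does whether a single added group has a similar effect on the 3,4-dichlorophenyl terminal aryl.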